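The source may hold more compounds than are shown below. What is called first, only, known or untested is meant among the compounds shown, and "the series" means these compounds.

Measured so far in an assay on isolated protein for inhibition of histone deacetylase 8 (Homo sapiens), with a stated time of 1 h; a lower number here means a stronger inhibitor, a higher number a weaker inhibitor:
compound 1 `O=C(COc1ccc2cc(/C=C3/SC(=O)NC3=O)ccc2c1)Nc1cccc(F)n1` gives 7200 nM;
compound 2 `Cc1cc(Br)ccc1NC(=O)COc1ccc2cc(/C=C3/SC(=O)NC3=O)ccc2c1` gives 7400 nM;
compound 3 `O=C(COc1ccc2cc(/C=C3/SC(=O)NC3=O)ccc2c1)Nc1ccc([N+](=O)[O-])cc1` gives 4000 nM.

The three compounds share one core and differ only in the group carried on the amide-type nitrogen. Compound 3 has the lowest of the three numbers, yet every gap is within the usual scatter: a 1.8-fold lower number from compound 1 to compound 3 (0.26 log units; within the scatter), a 1.9-fold lower number from compound 2 to compound 3 (0.27 log units; within the scatter), and between the other two a 1.0-fold higher number from compound 1 to compound 2 (0.01 log units; within the scatter). So far, swapping the group on that nitrogen has not moved the read-out in a way that can be told from repeat measurements.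

Compound 4 `Cc1cc(NC(=O)COc2ccc3cc(/C=C4/SC(=O)NC4=O)ccc3c2)no1` continues the same kind of exchange: 5-methyl-1,2-oxazol-3-yl in place of 4-nitrophenyl on an amide-type nitrogen. The three measured steps all bear on it, since each also replaced the group on this nitrogen, and each stayed within the scatter. No step beyond the scatter is therefore expected in this assay for compound 4, and its number is estimated at 6000 nM, within 2500 nM to 15000 nM. The expected step from its nearest measured relative is a 1.5-fold higher number from compound 3 to compound 4 (0.18 log units; within the scatter).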

Compound 4, half-maximal inhibitory concentration: > 50000 nM
Compound 4 ended at the assay's limit; the forecaster's own chance of this, stated with the estimate: 5%; middle value at least 8.3-fold (0.92 log units) from the limit.
By their numbers in this assay, from the lowest: compounds 3, 1 and 2 (each within the scatter of the next). At a limit, above all of these: compound 4.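

Unlike the earlier exchanges, this one clearly moves the read-out in this assay: the 5-methyl-1,2-oxazol-3-yl group gives an at least 12-fold higher number from compound 3 to compound 4 (1.09 log units; beyond the scatter) and an at least 6.9-fold higher number from compound 1 to compound 4 (0.84 log units; beyond the scatter) and also an at least 6.7-fold higher number from compound 2 to compound 4 (0.82 log units; beyond the scatter). Going by these compounds alone, the position is therefore less forgiving than the first three compounds suggested: compounds 1, 2 and 3 stay within the scatter of each other, while the one compound with a five-membered aromatic ring on this nitrogen falls far behind them. Compound 4 is read at a limit of the assay and not at a number: the limit of > 50000 nM in this assay, at which 1 of the 4 values shown sits.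

With only one five-membered ring shown, the effect of ring size cannot be separated from that of its hetero atoms or its methyl group. As far as these compounds go, it also remains open how a plain phenyl, an unsubstituted 1,2-oxazol-3-yl or a benzyl group on this nitrogen would read.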